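Imidazolylsulfonyl in place of phenylsulfonyl on a serotonin-6 antagonist

The source may hold more compounds than are shown below. What is called first, only, known or untested is meant among the compounds shown, and "the series" means these compounds.

Compound 1 `Cc1c(/C=N/N2CCN(C)CC2)c2ccccc2n1S(=O)(=O)c1ccc2ccccc2c1` gives 2040 nM in a functional assay on HEK293 cells for antagonist activity at 5-hydroxytryptamine receptor 6 (Homo sapiens), read by cAMP accumulation, with stated times of 10 min and 1 h; on this read-out lower numbers stand for stronger inhibition and higher numbers for weaker inhibition. Compound 2 `CN1CCN(/N=C/c2c(-c3ccccc3)n(S(=O)(=O)c3ccccc3)c3ccccc23)CC1` gives 1800 nM. Compound 3 `CN1CCN(/N=C/c2c(-c3ccccc3)n(S(=O)(=O)c3cccc4c(N(C)C)cccc34)c3ccccc23)CC1` gives 1400 nM.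

Compound 2 stands second highest of the three numbers. Its nearest neighbour is compound 1, whose number is within the scatter of that of compound 2, and compound 3, the furthest, is also within the scatter of compound 2. Across these three compounds, the sulfonyl substituent is varied among carbon-only aromatic rings and the numbers do not move beyond the scatter.

Compound 4 `CN1CCN(/N=C/c2c(-c3ccccc3)n(S(=O)(=O)c3nccn3C)c3ccccc23)CC1` carries 1-methyl-1H-imidazol-2-yl in place of phenyl on a sulfonyl sulfur. Among the measured compounds shown here, no measured pair shows this change, so its direction can only be judged from what the three measured compounds show, which is no movement beyond the scatter. A step of about the scatter, if anything toward a higher number, is expected from compound 2 to compound 4, namely a 1.2-fold higher number from compound 2 to compound 4 (0.09 log units; within the scatter). Compound 4 is therefore estimated at 2200 nM in this assay, with a range from 700 nM to 7000 nM.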

Compound 4, half-maximal inhibitory concentration: 3600 nM
Compound 4: middle estimate off by 1.6-fold (0.21 log units), on the low side, within the range that was stated.
By their numbers in this assay, from the lowest: compounds 3, 2, 1 and 4 (each within the scatter of the next, the first and the last beyond it).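

In this assay, among the compounds shown here, the step from phenyl to 1-methyl-1H-imidazol-2-yl on the sulfonyl sulfur gives a 2.0-fold higher number from compound 2 to compound 4 (0.30 log units; within the scatter), the first comparison here in which only this group changes. Compounds 1, 2 and 3 carry different sulfonyl groups but also differ elsewhere, so they could not isolate the group's contribution. At this position on the core of compound 2, a five-membered aromatic ring with two hetero atoms and two hydrogen-bond acceptors can therefore replace a carbon-only six-membered ring with the number staying within the scatter, and nothing given here explains the size of the step.

Going by these compounds, whether the same holds for an imidazol-2-yl without the methyl group, a pyridin-2-yl or a thiophen-2-yl on the sulfonyl sulfur remains open. So does whether the exchange behaves alike on the core of compound 1, which carries a methyl group where compound 2 carries a phenyl.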